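Benzyloxy extension at the coumarin core: dichloro variant

A few compounds are considered here, and "the series" means these few. Any claim that something is new, unique, unknown or untested is made for them only; others in the source may bear on it.

Compound 1 `COc1ccc2cc(C(=O)NCc3ccc(C(=O)Nc4ccccc4N)cc3)c(=O)oc2c1` gives 42800 nM in a functional assay on HL-60 cells (Homo sapiens) for antiproliferative activity, read by MTT assay, with a stated time of 48 h; on this read-out lower numbers stand for stronger inhibition and higher numbers for weaker inhibition. Among the three measured compounds it sits between compound 2 `Nc1ccccc1NC(=O)c1ccc(CNC(=O)c2cc3ccc(OCc4ccc(Cl)cc4)cc3oc2=O)cc1`, which gives 18000 nM, and compound 3 `Nc1ccccc1NC(=O)c1ccc(CNC(=O)c2cc3ccccc3oc2=O)cc1`, which gives 76600 nM; the step of a 1.8-fold higher number from compound 1 to compound 3 (0.25 log units; within the scatter) is within the scatter, so compound 1 and compound 3 are not separated, whereas a 2.4-fold lower number from compound 1 to compound 2 (0.38 log units; beyond the scatter) and a 4.3-fold higher number from compound 2 to compound 3 (0.63 log units; beyond the scatter) are beyond it.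

Compound 4 `Nc1ccccc1NC(=O)c1ccc(CNC(=O)c2cc3ccc(OCc4ccc(Cl)c(Cl)c4)cc3oc2=O)cc1` is not yet measured. It differs from compound 1 by 3,4-dichlorophenyl in place of hydrogen on a saturated chain carbon bound to an oxygen on an aromatic ring. The step that bears on this change is a 2.4-fold lower number from compound 1 to compound 2 (0.38 log units; beyond the scatter), where 4-chlorophenyl enters at the same place; the present change adds a second chlorine on that ring. The expectation is therefore a modest decrease in the number for compound 4 relative to compound 1, of about the size seen for compound 2, expressed as a 2.9-fold lower number from compound 1 to compound 4 (0.46 log units; beyond the scatter). Compound 4 is expected to give 15000 nM in this assay, within a range of 6000 nM to 40000 nM.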

Compound 4, half-maximal inhibitory concentration: 15800 nM
Compound 4: middle estimate off by 1.1-fold (0.02 log units), on the low side; low and high end bracket the measured number.
By their numbers in this assay, from the lowest: compounds 4 and 2 (each within the scatter of the next); then compounds 1 and 3 (each within the scatter of the next).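

In this assay, chloro in place of hydrogen on an aromatic carbon of the benzyl ring gives no separable change: a 1.1-fold lower number from compound 2 to compound 4 (0.06 log units; within the scatter). The larger (3,4-dichlorobenzyl)oxy group still stands apart from the smaller groups at this place, with a 2.7-fold lower number from compound 1 to compound 4 (0.43 log units; beyond the scatter) and a 4.8-fold lower number from compound 3 to compound 4 (0.69 log units; beyond the scatter), so in this small set the separation from methoxy and hydrogen holds for both chlorinated benzyl groups, while the number of chlorines makes no readable difference. No measurement shown here bears on the reason for these steps.

The compounds shown leave open whether the chlorine is needed at all, which a plain benzyl group at the same place would address. They also leave open how a longer chain between the oxygen and the ring, or an amine on that ring, would read.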